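The compounds below may be only part of what the source reports. "The series", "measured", "known", "first", "only" and "open" are said of these compounds alone.

Measured in a functional assay on thoracic aorta (strain Wistar) with Aorta (Rattus norvegicus) as the target, with a stated time of 120 min; on this read-out higher numbers stand for an effect only at larger amounts of compound and lower numbers for an effect already at smaller amounts:
- Compound 1 `CCCCNC(=O)NS(=O)(=O)c1ccc(OCCCO[N+](=O)[O-])cc1`: 900 nM
- Compound 2 `CCCCNC(=O)NS(=O)(=O)c1ccc(OCC(CO[N+](=O)[O-])O[N+](=O)[O-])cc1`: 2.4 nM
- Compound 3 `CCCCNC(=O)NS(=O)(=O)c1ccc(OCc2no[n+]([O-])c2-c2ccccc2)cc1`: 740 nM

Compound 1 gives 900 nM and compound 3 gives 740 nM, two values within the usual scatter of each other. Compound 2, at 2.4 nM, lies far lower than either, so compound 3 belongs to the high end of this small set.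

Compound 4 `CCCCNC(=O)NS(=O)(=O)c1ccc(OCc2no[n+]([O-])c2C(N)=O)cc1` keeps the rest of compound 3 and changes one group, with carbamoyl in place of phenyl on an aromatic carbon.

Within the data shown here, no measured step makes this replacement. Among the measured compounds shown here, the only step available, a 380-fold lower number from compound 1 to compound 2 (2.57 log units; beyond the scatter), concerns a nitrooxy group on a saturated chain carbon. It shows that one change among these compounds can move the number a long way, but it gives neither the size nor the direction of the change here.

The expectation therefore starts from compound 3 at 740 nM in this assay, with a wide margin on both sides. A slight lean towards a lower number is a judgement and has not been measured. The estimated change is small: a 1.9-fold lower number from compound 3 to compound 4 (0.27 log units; within the scatter). For compound 4 the estimate is 400 nM, with an expected range of 70 nM to 2000 nM.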

Compound 4, half-maximal effective concentration: 10 nM
The estimate for compound 4 lay 40-fold (1.60 log units) above the measured number; the measured number lies below the stated range.
By their numbers in this assay, from the lowest: compound 2; then compound 4; then compounds 3 and 1 (each within the scatter of the next).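

In this assay, the carbon of the five-membered aromatic ring that carries phenyl in compound 3 proves highly sensitive to its substituent: carbamoyl in place of phenyl gives a 74-fold lower number from compound 3 to compound 4 (1.87 log units; beyond the scatter), a large step from a single change. Compounds 1 and 3 had given numbers within the scatter of each other, which could have suggested that exchanging the chain for the ring-bearing group matters little, but with carbamoyl on the ring the exchange gives a 90-fold lower number from compound 1 to compound 4 (1.95 log units; beyond the scatter), so the outcome of that exchange depends on what the ring carries. The change removes a six-membered aromatic ring of carbon only and brings in a smaller group with a hydrogen-bond donor and acceptor, but no measurement offered here explains why the number moves.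

Going by these compounds, with only phenyl and carbamoyl at this position, it remains open whether removing phenyl or adding carbamoyl drives the step, and a methyl group, a nitrile or a carboxylic acid on the same ring carbon could help separate the two. On these data alone, it also remains open whether the step would keep its size if the butyl chain of the shared core gave way to a cyclohexyl ring.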